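The source may hold more compounds than are shown below. What is called first, only, known or untested is meant among the compounds shown, and "the series" means these compounds.

Compound 1 `Nc1ccc2sc(NC(=S)NC(=O)c3ccccc3)nc2c1` gives 38600 nM in a functional assay on MCF7 cells (Homo sapiens) for cytotoxicity, read by MTT assay, with a stated time of 24 h; on this read-out higher numbers stand for weaker inhibition and lower numbers for stronger inhibition. Compound 2 `O=C(NC(=S)Nc1nc2ccccc2s1)c1ccccc1` gives 37300 nM in this assay; the change between the two is hydrogen in place of amino on an aromatic carbon, and the step it made is a 1.0-fold lower number from compound 1 to compound 2 (0.01 log units; within the scatter). Compound 3 `CCCCC(=O)NC(=S)Nc1nc2cc(N)ccc2s1` gives 44700 nM in this assay; its core differs from that of compound 1 by butyl in place of phenyl on a carbonyl carbon, a step of a 1.2-fold higher number from compound 1 to compound 3 (0.06 log units; within the scatter). Compound 4 `CCCCC(=O)NC(=S)Nc1nc2ccccc2s1` has not yet been measured in this assay. It differs from compound 3 by hydrogen in place of amino on an aromatic carbon, the same change as that seen between compound 1 and compound 2, at a place described in the same words. Because that earlier change gave a 1.0-fold lower number from compound 1 to compound 2 (0.01 log units; within the scatter), compound 4 is expected to show a step of a 1.0-fold lower number from compound 3 to compound 4 (0.01 log units; within the scatter). In this assay compound 4 is therefore estimated at 44000 nM, with a likely range from 22000 nM to 88000 nM.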

Compound 4, half-maximal inhibitory concentration: 36600 nM
Compound 4: the middle estimate sits 1.2-fold (0.08 log units) above what was measured; low and high end bracket the measured number.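

In this assay, hydrogen in place of amino on an aromatic carbon gave a 1.2-fold lower number from compound 3 to compound 4 (0.09 log units; within the scatter), which agrees with the earlier step: the same change on two cores in this assay, a 1.0-fold lower number (0.01 log units; within the scatter) from compound 1 to compound 2 and a 1.2-fold lower number (0.09 log units; within the scatter) from compound 3 to compound 4, 1.2-fold (0.07 log units) apart, within the scatter of two such steps. Butyl in place of phenyl on a carbonyl carbon gave a 1.0-fold lower number from compound 2 to compound 4 (0.01 log units; within the scatter), and this change also carries from one core to the other: the same change on two cores in this assay, a 1.2-fold higher number (0.06 log units; within the scatter) from compound 1 to compound 3 and a 1.0-fold lower number (0.01 log units; within the scatter) from compound 2 to compound 4, 1.2-fold (0.07 log units) apart, within the scatter of two such steps. Among the compounds shown here, every step here lies within the scatter, so the agreement shows only that neither change gave a measurable step on either core, not that a change with a real effect would carry over in the same way.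

The compounds shown leave open whether a nitro or methoxy group on that aromatic carbon, or a longer chain or a pyridine ring on the carbonyl carbon, would give a step beyond the scatter.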